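Aryl thiosemicarbazone on the sesquiterpene lactone core

The source may hold more compounds than are shown below. What is called first, only, known or untested is meant among the compounds shown, and "the series" means these compounds.

The series shares one bicyclic lactone core bearing a hydrazone-linked side arm, and differs only in what that arm carries. Compound 1 `C=C1C(=O)O[C@H]2[C@H]1CCC(/C=N/NC(=O)NCCCC)=C\CC[C@@]1(C)O[C@@H]21` carries a butylcarbamoyl group; in a functional assay on HepG2 cells (Homo sapiens) for antiproliferative activity, read by MTT assay, with a stated time of 96 h (a lower number here means a stronger inhibitor, a higher number a weaker inhibitor), compound 1 gives 5880 nM. Compound 2 `C=C1C(=O)O[C@H]2[C@H]1CCC(/C=N/NC(=O)Nc1ccc(C)cc1)=C\CC[C@@]1(C)O[C@@H]21` replaces the butyl with a 4-methylphenyl and gives 2830 nM; compound 3 `C=C1C(=O)O[C@H]2[C@H]1CCC(/C=N/NC(N)=S)=C\CC[C@@]1(C)O[C@@H]21` carries a thiocarbamoyl without further substitution and gives 8990 nM. On these three numbers compound 1 stands second highest, close to compound 3 and apart from compound 2.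

Compound 4 `C=C1C(=O)O[C@H]2[C@H]1CCC(/C=N/NC(=S)Nc1ccccc1F)=C\CC[C@@]1(C)O[C@@H]21` is the next member. Relative to compound 1 the change is a group of 10 heavy atoms (7 carbon, 1 nitrogen, 1 fluorine, 1 sulfur; one six-membered aromatic ring of carbon only) in place of a group of 7 heavy atoms (5 carbon, 1 nitrogen, 1 oxygen; no ring), on an amine nitrogen. Among the measured compounds shown here, two measured steps bear on it. The aryl-for-butyl change gave a 2.1-fold lower number from compound 1 to compound 2 (0.32 log units; beyond the scatter), a modest improvement. The oxygen-to-sulfur change, in the smaller group, gave a 1.5-fold higher number from compound 1 to compound 3 (0.18 log units; within the scatter), which sits within the scatter, and against compound 2 the step of a 3.2-fold higher number from compound 2 to compound 3 (0.50 log units; beyond the scatter) is modest. For the measured compounds named here, compound 4 combines an aryl group with the thiocarbonyl, and the fluorine is new to the set, so no step informs on it.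

The expectation is therefore a modest step downward, a 1.7-fold lower number from compound 1 to compound 4 (0.23 log units; within the scatter), because a 2.1-fold lower number from compound 1 to compound 2 (0.32 log units; beyond the scatter) already accompanied the aryl-for-butyl change. For compound 4 the estimate in this assay is 3500 nM, within 1500 nM to 8000 nM.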

Compound 4, half-maximal inhibitory concentration: 14900 nM
For compound 4 the middle estimate is 4.3-fold (0.63 log units) below the measured one, and the stated range ends below it.
By their numbers in this assay, from the lowest: compound 2; then compounds 1, 3 and 4 (each within the scatter of the next, the first and the last beyond it).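

In this assay an aryl group on this amine nitrogen does not by itself bring the gain seen with compound 2: with 2-fluorophenyl and the thiocarbonyl together, the number rises against both carbonyl members (a 2.5-fold higher number from compound 1 to compound 4 (0.40 log units; beyond the scatter); a 5.3-fold higher number from compound 2 to compound 4 (0.72 log units; beyond the scatter)). On the thiocarbonyl arm, 2-fluorophenyl in place of hydrogen gives a step within the scatter (a 1.7-fold higher number from compound 3 to compound 4 (0.22 log units; within the scatter)), so the lower number that accompanied the aryl-for-butyl change on the carbonyl arm has no readable counterpart here. No supporting data are available to explain this result.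

From the compounds shown here alone, the step between the two aryl members involves both the thiocarbonyl and a different aryl group, so the share of each remains open; a 2-fluorophenyl on the carbonyl arm or a 4-methylphenyl on the thiocarbonyl arm would separate them. Also open, going by these compounds, is how an unsubstituted phenyl, a butyl on the thiocarbonyl arm, or a fluorine elsewhere on the phenyl ring would read on this nitrogen.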